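The compounds below may be only part of what the source reports. "The series", "measured", "known", "first", "only" and "open" are said of these compounds alone.

Within the data shown here, in a functional assay on HepG2 cells (Homo sapiens) for antiproliferative activity, read by MTT assay, with a stated time of 48 h (a lower number here means a stronger inhibitor, a higher number a weaker inhibitor), compound 2 (`COc1ccc(CN(C(=O)Cn2cc(COc3ccccc3)nn2)c2cc(OC)c(OC)c(OC)c2)cc1`) gives 20500 nM, the higher of the two numbers measured so far, while compound 1 (`COc1ccc(CN(C(=O)Cn2cc(COc3ccc4ccc(=O)oc4c3)nn2)c2cc(OC)c(OC)c(OC)c2)cc1`) gives 1300 nM. The next comparison is with compound 3 (`COc1ccc(CN(C(=O)Cn2cc(CSc3nc4ccccc4s3)nn2)c2cc(OC)c(OC)c(OC)c2)cc1`): (1,3-benzothiazol-2-yl)sulfanyl in place of phenoxy on a saturated chain carbon bound to an aromatic carbon. In short, (1,3-benzothiazol-2-yl)sulfanyl stands in place of phenoxy on a saturated chain carbon bound to an aromatic carbon.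

Among the measured compounds shown here, only one measured step bears on this change: a 16-fold higher number from compound 1 to compound 2 (1.20 log units; beyond the scatter). That large step goes from a bigger aromatic group to a smaller one, on an oxygen on a saturated carbon. Compound 3 also carries a bigger aromatic group than compound 2, but its group is a different one and is attached through sulfur. For the measured compounds named here, no measured compound shows the effect of that sulfanyl link, so only part of the step seen with compound 1 is carried over. A lower number than that of compound 2 is expected in this assay, with a step beyond the scatter still uncertain. The expected step is a 3.4-fold lower number from compound 2 to compound 3 (0.53 log units; beyond the scatter). For compound 3 the estimated value is 6000 nM, within an expected range of 1800 nM to 20000 nM.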

Compound 3, half-maximal inhibitory concentration: 49200 nM
The estimate for compound 3 lay 8.2-fold (0.91 log units) below the measured number; measured number above the stated range.
By their numbers in this assay, from the lowest: compound 1; then compound 2; then compound 3.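

In this assay, a second aromatic ring at this place does not by itself lower the number: (1,3-benzothiazol-2-yl)sulfanyl in place of phenoxy gives a 2.4-fold higher number from compound 2 to compound 3 (0.38 log units; beyond the scatter), whereas the earlier step, a 16-fold higher number from compound 1 to compound 2 (1.20 log units; beyond the scatter), had left open whether the larger group of compound 1 helped simply by its size. The group of compound 1 and the (1,3-benzothiazol-2-yl)sulfanyl group both carry two aromatic rings, yet they are separated by a 38-fold higher number from compound 1 to compound 3 (1.58 log units; beyond the scatter), so among these compounds the number at this place follows the identity of the group and not its ring count or its heavy-atom count. No measured information on these compounds accounts for this order.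

The compounds shown leave open how much of the step to compound 3 belongs to the sulfur link and how much to the ring system, since both change together, and a phenylsulfanyl group at this place would separate the two. Also open, going by these compounds, is how this position reads with no aromatic ring on the chain at all, for example with a dimethylamino group or a carboxylic acid.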